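One Chlorine on the Chain: From Compound 2 to Compound 3

The source may hold more compounds than are shown below. What is called first, only, known or untested is meant among the compounds shown, and "the series" means these compounds.

Compound 1 `CCOC(=O)c1sc2nc(-c3cccs3)cc(-c3ccccc3)c2c1N`: > 7500 nM
Compound 2 `CCC[S+]([O-])c1sc2nc(-c3cccs3)cc(-c3ccccc3)c2c1N`: 2.1 nM

In an assay for inhibition of 15-hydroxyprostaglandin dehydrogenase [NAD(+)] (Homo sapiens), read by fluorescence, with a stated time of 15 min, in the presence of a further agent that is not named here (a lower number here means a stronger inhibitor, a higher number a weaker inhibitor), compound 2 gives 2.1 nM, the only measured number among the two compounds shown. For compound 1 the value > 7500 nM is a limit of the assay, not a number. The step of an at least 3500-fold lower number from compound 1 to compound 2 (3.55 log units; beyond the scatter) is therefore known only as a lower bound, because of the limit of > 7500 nM in this assay, at which 1 of the 2 values shown sits. Going by the values given here, that step swaps the whole group on the aromatic carbon of the shared core and is the only measured comparison available.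

Compound 3 `Nc1c([S+]([O-])CCCCl)sc2nc(-c3cccs3)cc(-c3ccccc3)c12` is not yet measured. It differs from compound 2 by chloro in place of hydrogen on a saturated chain carbon, three bonds along the chain from a sulfur. Among the compounds with values here, no measured step touches the far end of this chain; the one measured step concerns a different group at a different place, so it gives no direct guide to the size or direction of this change. With nothing pointing either way, the expectation for compound 3 is a step of a 1.2-fold higher number from compound 2 to compound 3 (0.08 log units; within the scatter) that stays within the usual scatter. The estimated value for compound 3 in this assay is 2.5 nM, with a range from 0.8 nM to 8 nM.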

Compound 3, half-maximal inhibitory concentration: 4 nM
The estimate for compound 3 lay 1.6-fold (0.20 log units) below the measured number; low and high end bracket the measured number.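

In this assay, the change from propyl to 3-chloropropyl gives a 1.9-fold higher number from compound 2 to compound 3 (0.28 log units; within the scatter), so at this far end of the chain, a chlorine in place of a hydrogen produces no difference that can be told apart from the ordinary spread of repeated measurements. Compound 1 gives > 7500 nM, which is a limit of the assay and not a number. The large difference made by the group on the aromatic carbon therefore remains with the chlorine present, as an at least 1800-fold lower number from compound 1 to compound 3 (3.27 log units; beyond the scatter), but this step too is known only as a bound: the limit of > 7500 nM in this assay, at which 1 of the 3 values shown sits.

One chlorine at one place says little about how much the chain end can vary, and a longer chain, a hydroxyl group, an amine or a carboxylic acid at that end could still move the number in either direction. Going by these compounds, it also remains open which part of the group on the aromatic carbon matters for the large step, and a sulfone or a simple thioether on that carbon would help to separate the contribution of the sulfur from that of its oxygen.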